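This account rests on a few compounds, and the source may have more. Where it says the series, first, only, none or still open, it means among the compounds named here.

Working notes on the series. Compound 1 `COC(=O)N1N=C(c2ccccc2)CC1c1cc(OC)c(OC)c(OC)c1` gives 2180 nM in a functional assay on HeLa cells (Homo sapiens) for antiproliferative activity, read by MTT assay, with a stated time of 48 h; a lower number here means a stronger inhibitor of growth, a higher number a weaker inhibitor of growth. Compound 2 `CCOC(=O)N1N=C(c2ccccc2)CC1c1cc(OC)c(OC)c(OC)c1` gives 8230 nM, and a 3.8-fold higher number from compound 1 to compound 2 (0.58 log units; beyond the scatter) follows from methyl in place of hydrogen on a saturated chain carbon bound to an oxygen next to a carbonyl group. Compound 3 `CCOC(=O)N1N=C(c2cccc(O)c2)CC1c1cc(OC)c(OC)c(OC)c1` gives 3280 nM; the step is a 2.5-fold lower number from compound 2 to compound 3 (0.40 log units; beyond the scatter). The difference between the core of compound 3 and the core of compound 1 is not broken down here.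

Compound 4 `CCCOC(=O)N1N=C(c2cccc(O)c2)CC1c1cc(OC)c(OC)c(OC)c1` is not yet measured. It differs from compound 3 by methyl in place of hydrogen on a saturated chain carbon, two bonds along the chain from an oxygen next to a carbonyl group. This is the same kind of change as that from compound 1 to compound 2, though not the same: there the carbon was bound to an oxygen next to a carbonyl group, here it is two bonds along the chain from an oxygen next to a carbonyl group. Because compound 1 to compound 2 showed a 3.8-fold higher number from compound 1 to compound 2 (0.58 log units; beyond the scatter), a rise of similar but uncertain size is expected, a 2.3-fold higher number from compound 3 to compound 4 (0.36 log units; beyond the scatter). For compound 4 the estimate is 7500 nM, between 2500 nM and 22000 nM.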

Compound 4, concentration for 50% growth inhibition: > 10000 nM
Compound 4: a limit, no number; the forecaster's own chance of this, stated with the estimate: 5%; middle value at least 1.3-fold (0.12 log units) away from the limit.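

In this assay compound 4 gives > 10000 nM as a limit of the assay, not a number. Methyl in place of hydrogen on the chain gives a higher number on both cores (an at least 3.0-fold higher number from compound 3 to compound 4 (0.48 log units; beyond the scatter)), so the direction carries from one core to the other, while the sizes of the two steps cannot be compared: the same change on two cores in this assay, a 3.8-fold higher number (0.58 log units; beyond the scatter) from compound 1 to compound 2 and an at least 3.0-fold higher number (0.48 log units; beyond the scatter) from compound 3 to compound 4; the limit leaves it open whether they differ. This rests on two pairs only, one of them read against a limit: the limit of > 10000 nM in this assay, at which 1 of the 4 values shown sits.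

The compounds shown leave open how a chain longer than propyl, or a branched chain, would read in this assay on either core. Also open, from the compounds shown here alone, is how an amine in place of the hydroxy of compound 3 would read.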